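Furan for Oxane: Weak Cytotoxicity Expected to Stay Weak

The source may hold more compounds than are shown below. What is called first, only, known or untested is meant among the compounds shown, and "the series" means these compounds.

Measured compounds in a functional assay on HeLa cells (Homo sapiens) for cytotoxicity, read by MTT assay; on this read-out lower numbers stand for stronger inhibition and higher numbers for weaker inhibition:
- compound 1 `CC(=O)OCCO[C@H](CC=C(C)C)C1=CC(=O)c2c(O)ccc(O)c2C1=O` gives 41500 nM
- compound 2 `CC(C)=CC[C@@H](OC(=O)CC(C)(O)c1ccccc1)C1=CC(=O)c2c(O)ccc(O)c2C1=O` gives 85700 nM
- compound 3 `CC(C)=CC[C@@H](OC(=O)C1CCCCO1)C1=CC(=O)c2c(O)ccc(O)c2C1=O` reaches only the limit of the assay, > 100000 nM

All three share one core and differ only in the group on the oxygen at the saturated carbon. Compound 3 stands at the weak end: its value is a limit, not a number, so only a floor is known. The change from compound 1 to compound 3, (oxan-2-yl)carbonyl in place of 2-acetoxyethyl on an oxygen on a saturated carbon, gives an at least 2.4-fold higher number from compound 1 to compound 3 (0.38 log units; beyond the scatter). The change from compound 2 to compound 3, oxan-2-yl in place of 2-hydroxy-2-phenylpropyl on a carbonyl carbon, gives an at least 1.1-fold higher number from compound 2 to compound 3 (0.06 log units; that floor lies within the scatter).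

Compound 4 `CC(C)=CC[C@@H](OC(=O)c1ccco1)C1=CC(=O)c2c(O)ccc(O)c2C1=O` is not yet measured. It differs from compound 3 by furan-2-yl in place of oxan-2-yl on a carbonyl carbon. Both steps that end at compound 3 show weak inhibition there, and the 2-hydroxy-2-phenylpropyl and oxan-2-yl groups on the carbonyl carbon sit within scatter of each other, so the furan-2-yl group is expected to change little; the expected step is a number no higher from compound 3 to compound 4 (the limit leaves the size open). Compound 4 is therefore estimated at 100000 nM, between 40000 nM and 250000 nM, with a real chance that only a limit is reported again.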

Compound 4, half-maximal inhibitory concentration: 80300 nM
The estimate for compound 4 lay 1.2-fold (0.10 log units) above the measured number, within the range that was stated.
By their numbers in this assay, from the lowest: compounds 1, 4 and 2 (each within the scatter of the next, the first and the last beyond it). At a limit, above all of these: compound 3.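

In this assay, furan-2-yl in place of oxan-2-yl on the carbonyl carbon swaps a six-membered non-aromatic ring for a five-membered aromatic ring, and this position now yields a measured number with a ring attached (an at least 1.2-fold lower number from compound 3 to compound 4 (0.09 log units; that floor lies within the scatter)), although that floor does not establish a real change. Compound 4 also cannot be told apart from the two other measured compounds, whether furan-2-yl replaces 2-hydroxy-2-phenylpropyl on the carbonyl carbon (a 1.1-fold lower number from compound 2 to compound 4 (0.03 log units; within the scatter)) or (furan-2-yl)carbonyl replaces 2-acetoxyethyl on the oxygen on a saturated carbon (a 1.9-fold higher number from compound 1 to compound 4 (0.29 log units; within the scatter)), so these quite different groups give results that stay within the usual scatter of compound 4. The value of compound 3 remains a limit, not a number, so the true size of its step to compound 4 stays unknown: the limit of > 100000 nM in this assay, at which 1 of the 4 values shown sits.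

Going by these compounds, whether an amine or a carboxylic acid on this carbonyl carbon would shift the number beyond the scatter remains open. The compounds shown also leave open whether a longer carbon chain here would behave any differently from the ring groups.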